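Chain extension in a long-chain amide series

This account rests on a few compounds, and the source may have more. Where it says the series, first, only, none or still open, it means among the compounds named here.

Measured compounds:
- compound 1, `CCCCCCCCCCCCC(C)(C)C(=O)Nc1c(OC)cc(OC)cc1OC`, 63 nM
- compound 2, `CCCCCCCCCCCCCCCC(=O)Nc1c(OC)cc(OC)cc1OC`, 54 nM
- compound 3, `CCCCCCCCCCCCCCC(C)(C)C(=O)Nc1c(OC)cc(OC)cc1OC`, 44 nM

All three were run in an assay on microsomes from intestine for inhibition of acyl-CoA:cholesterol acyltransferase (Oryctolagus cuniculus); on this read-out lower numbers stand for stronger inhibition and higher numbers for weaker inhibition. Compound 2 gives 54 nM and compound 1 gives 63 nM; the two numbers lie within the scatter of each other, as do compound 2 and compound 3, which gives 44 nM. None of the three can be singled out as the strongest.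

Compound 3 is made from compound 1 by ethyl in place of hydrogen on a saturated chain carbon, ten or more bonds along the chain from a carbonyl carbon. Within the data shown here, the step of a 1.4-fold lower number from compound 1 to compound 3 (0.16 log units; within the scatter) is the only measured instance of this change, and it did not move the number beyond the scatter.

The unmeasured compound 4, `CCCCCCCCCCCCCCCCCC(=O)Nc1c(OC)cc(OC)cc1OC`, is made from compound 2 by ethyl in place of hydrogen on a saturated chain carbon, ten or more bonds along the chain from a carbonyl carbon. The two "place" descriptions agree word for word, so this is the same change on a second core. The two cores, those of compound 1 and compound 2, share their atoms but join them differently; the difference between them is not broken down here.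

With a single prior example, the expectation for compound 4 in this assay rests on the small step seen for compound 3 from compound 1 and on compound 2 giving 54 nM. The step from compound 2 to compound 4 is expected to be a 1.3-fold lower number from compound 2 to compound 4 (0.11 log units; within the scatter), within the scatter. Compound 4 is therefore estimated at 42 nM, with a range from 20 nM to 90 nM.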

Compound 4, half-maximal inhibitory concentration: 52 nM
The estimate for compound 4 lay 1.2-fold (0.09 log units) below the measured number; low and high end bracket the measured number.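

In this assay the new step is a 1.0-fold lower number from compound 2 to compound 4 (0.02 log units; within the scatter), so ethyl in place of hydrogen on a saturated chain carbon, ten or more bonds along the chain from a carbonyl carbon, leaves the number within the scatter on the core of compound 2, as it did on the core of compound 1. The two readings of this change do not differ: the same change on two cores in this assay, a 1.4-fold lower number (0.16 log units; within the scatter) from compound 1 to compound 3 and a 1.0-fold lower number (0.02 log units; within the scatter) from compound 2 to compound 4, 1.4-fold (0.14 log units) apart, within the scatter of two such steps

Within these two cores the change therefore carries over as a step too small to separate from the scatter; this does not show that it gives a real gain on either core, and two small steps say nothing about how it would behave on any further core.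

As far as these compounds go, whether a longer chain, or a chain carrying an amine or a carboxylic acid, would move the number beyond the scatter remains open. The compounds shown also keep the amide and the methoxy groups throughout, so the effect of exchanging a methoxy group for a hydroxy group or a chlorine atom, or of replacing the amide with a urea, is equally open.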